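Replacing the aryl group of compound 2 with 4-methoxy-3-nitrophenyl

The source may report more compounds than this note shows. Statements on the series, on what has been measured and on what is new or still open speak of the compounds shown alone.

Of the compounds shown here, two with a shared core have been measured so far in a functional assay on A549 cells (Homo sapiens) for cytotoxicity, read by MTT assay, with a stated time of 48 h; a higher number here means a weaker inhibitor, a lower number a stronger inhibitor. Compound 1 `COc1ccc(C2=NOC(COc3ccc(-c4nnnn4-c4cc(OC)c(OC)c(OC)c4)cc3N)C2)cc1N` gives 2080 nM, and compound 2 `COc1ccc(F)c(C2=NOC(COc3ccc(-c4nnnn4-c4cc(OC)c(OC)c(OC)c4)cc3N)C2)c1` gives 1510 nM. Going by the values given here, the only measured step is a 1.4-fold lower number from compound 1 to compound 2 (0.14 log units; within the scatter), so compound 2 cannot be told apart from compound 1 on these numbers.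

The next compound is compound 3 `COc1ccc(C2=NOC(COc3ccc(-c4nnnn4-c4cc(OC)c(OC)c(OC)c4)cc3N)C2)cc1[N+](=O)[O-]`, and the change is 4-methoxy-3-nitrophenyl in place of 2-fluoro-5-methoxyphenyl on a carbon with a double bond to nitrogen. Here, 4-methoxy-3-nitrophenyl takes the place of 2-fluoro-5-methoxyphenyl on a carbon with a double bond to nitrogen of a five-membered non-aromatic ring with 1 nitrogen and 1 oxygen.

Among the compounds with values here, the one measured step that bears on this exchange is at the same place, and it is small: a 1.4-fold lower number from compound 1 to compound 2 (0.14 log units; within the scatter). On that basis, no step beyond the scatter is expected in this assay. Within the data shown here, this is thin evidence, since no compound carrying 4-methoxy-3-nitrophenyl has yet been measured. The expected step is a 1.2-fold higher number from compound 2 to compound 3 (0.08 log units; within the scatter). Compound 3 is estimated at 1800 nM, with an expected range of 700 nM to 5000 nM.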

Compound 3, half-maximal inhibitory concentration: 2220 nM
For compound 3 the middle estimate is 1.2-fold (0.09 log units) below the measured one; measured number inside the range.
By their numbers in this assay, from the lowest: compounds 2, 1 and 3 (each within the scatter of the next).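

At the position on a carbon with a double bond to nitrogen, a third aryl group now gives a reading in this assay, and putting 4-methoxy-3-nitrophenyl in place of 2-fluoro-5-methoxyphenyl gives a 1.5-fold higher number from compound 2 to compound 3 (0.17 log units; within the scatter). Going by these compounds alone, the new compound also provides the first exchange of one group on this aryl ring, as nitro in place of amino on an aromatic carbon gives a 1.1-fold higher number from compound 1 to compound 3 (0.03 log units; within the scatter), so this narrower change cannot be told from the scatter either. All three aryl groups shown therefore remain indistinguishable in this assay, and no supporting evidence is available to explain this result.

The compounds shown leave open whether a carboxylic acid or a longer alkyl chain at this position would produce a step beyond the scatter. Within the data shown here, they also leave open what would happen if the amino group carried by the shared core in all three compounds gave way to a hydroxyl group, since every step so far lies at the aryl group on the carbon with a double bond to nitrogen.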